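Compound 3 to compound 4: fluoro replaces bromo

This account rests on a few compounds, and the source may have more. Where it says the series, first, only, none or still open, it means among the compounds named here.

Measured in an ADME assay on HEK293 cells (Homo sapiens) for cytotoxicity, read by MTT assay, with a stated time of 72 h; on this read-out higher numbers stand for weaker inhibition and lower numbers for stronger inhibition:
Compound 1 `O=C(CN1CCN(C(=O)c2ccc(F)cc2)CC1)N1CCN(CCCc2c[nH]c3ccccc23)CC1` gives 141000 nM
Compound 2 `O=C(CN1CCN(C(=O)c2ccc(Cl)cc2)CC1)N1CCN(CCCc2c[nH]c3ccc(F)cc23)CC1` gives 44500 nM
Compound 3 `O=C(CN1CCN(C(=O)c2ccc(Br)cc2)CC1)N1CCN(CCCc2c[nH]c3ccc(F)cc23)CC1` gives 60500 nM

Compound 3 stands second highest of these three numbers, within the scatter of compound 2 and clearly under compound 1. Compound 4 `O=C(CN1CCN(C(=O)c2ccc(F)cc2)CC1)N1CCN(CCCc2c[nH]c3ccc(F)cc23)CC1` differs from compound 3 by one exchange (fluoro in place of bromo on an aromatic carbon), fluoro in place of bromo on an aromatic carbon. Among the measured compounds shown here, the one measured halogen exchange, bromo in place of chloro (a 1.4-fold higher number from compound 2 to compound 3 (0.13 log units; within the scatter)), stayed within the scatter. Compound 1 (141000 nM) carries the same 4-fluorophenyl group, but its core differs, so it bears on this only loosely. No shift beyond the scatter is therefore expected in this assay, and the estimated step is small (a 1.1-fold higher number from compound 3 to compound 4 (0.03 log units; within the scatter)). Compound 4 is estimated at 65000 nM (expected range 35000 nM to 120000 nM).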

Compound 4, half-maximal inhibitory concentration: 102000 nM
Beside the measured number, compound 4's estimate is 1.6-fold (0.20 log units) below it; low and high end bracket the measured number.
By their numbers in this assay, from the lowest: compounds 2, 3, 4 and 1 (each within the scatter of the next, the first and the last beyond it).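

In this assay, the three halogens on this aromatic carbon can now be set side by side. Fluoro in place of bromo gives a 1.7-fold higher number from compound 3 to compound 4 (0.23 log units; within the scatter), whereas fluoro in place of chloro gives a 2.3-fold higher number from compound 2 to compound 4 (0.36 log units; beyond the scatter), so only the exchange from chloro moves the number beyond the scatter, and modestly. Fluoro in place of hydrogen on the core, with the 4-fluorophenyl group kept, gives a 1.4-fold lower number from compound 1 to compound 4 (0.14 log units; within the scatter). Nothing available explains these differences. The compounds shown leave open how a methoxy group or a nitrile on this aromatic carbon would read.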